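The source may hold more compounds than are shown below. What is called first, only, known or untested is meant among the compounds shown, and "the series" means these compounds.

Of the compounds shown here, three that share one core have been measured in a functional assay on PC-3 cells (Homo sapiens) for antiproliferative activity, read by MTT assay, with a stated time of 12 h (on this read-out lower numbers stand for stronger inhibition and higher numbers for weaker inhibition), and a fourth awaits measurement. Compound 1 `COc1cc(OC)c2c(=O)cc(/C=C/c3ccc([N+](=O)[O-])cc3)oc2c1` carries a nitro group on an aromatic carbon. In this assay compound 1 reaches only the limit of the assay, > 40000 nM. Compound 2 `COc1cc(OC)c2c(=O)cc(/C=C/c3ccncc3)oc2c1` likewise gives only a limit in this assay, > 40000 nM. Compound 3 `COc1cc(OC)c2c(=O)cc(/C=C/c3ccc(OCC4CC4)cc3)oc2c1` carries cyclopropylmethoxy where compound 1 has nitro; in this assay compound 3 also stops at a limit, > 40000 nM. The single step that connects two of these compounds, a step that the two limits leave unreadable from compound 1 to compound 3, cannot be read because of the limit of > 40000 nM in this assay, at which 3 of the 3 values shown sit. Compound 3 thus stands nowhere in particular among the numbers: all three measured values sit at the same limit, and no ordering among compounds 1, 2 and 3 can be drawn.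

Compound 4 `COc1cc(OC)c2c(=O)cc(/C=C/c3ccccc3)oc2c1` is reached from compound 3 by one change, (hydrogen in place of cyclopropylmethoxy on an aromatic carbon). Among the compounds with values here, no measured step bears on this change with a readable size; the only step that touches compound 3, a step that the two limits leave unreadable from compound 1 to compound 3, is itself hidden by the limit. Nothing in the numbers suggests that this change should bring the value below the limit, so in this assay compound 4 is expected to sit at or near that limit as well, with the estimated step of a number no higher from compound 3 to compound 4 (the limit leaves the size open) taken as none beyond the scatter. The estimate for compound 4 is 40000 nM, with a range from 10000 nM to 120000 nM.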

Compound 4, half-maximal inhibitory concentration: > 40000 nM
Compound 4 was reported as a limit; the forecaster's own chance of this, stated with the estimate: 75%; the middle value lies on the limit itself.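

No new step can be read in this assay between compound 4 and compound 1, compound 2 or compound 3, because each of these compounds stops at a limit: the limit of > 40000 nM in this assay, at which 4 of the 4 values shown sit. The compounds shown leave open how large any of these changes is, and which group on the shared core would give a readable value.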